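This account rests on a few compounds, and the source may have more. Where it says the series, first, only, none or still open, it means among the compounds named here.

Working notes on the series. Compound 2 `CCCCc1ccc(CNC(=O)Nc2ccccc2)c(=O)n1Cc1ccc(-c2ccccc2-c2nn[nH]n2)cc1` carries a (phenylcarbamoyl)amino group on the saturated chain carbon bound to an aromatic carbon of the shared core. In a functional assay (aorta) for antagonist activity, with Oryctolagus cuniculus as the target (a lower number here means a stronger inhibitor, a higher number a weaker inhibitor), compound 2 gives 30 nM, the highest number among the three measured compounds. Compound 1 `CCCCc1ccc(CNC(=O)OC(C)(C)C)c(=O)n1Cc1ccc(-c2ccccc2-c2nn[nH]n2)cc1` gives 10 nM in this assay, and compound 3 `CCCCc1ccc(CN(Cc2ccccc2)C(C)=O)c(=O)n1Cc1ccc(-c2ccccc2-c2nn[nH]n2)cc1` gives 1 nM. The measured steps are a 3.0-fold higher number from compound 1 to compound 2 (0.48 log units; beyond the scatter), a 10-fold lower number from compound 1 to compound 3 (1.00 log units; beyond the scatter) and a 30-fold lower number from compound 2 to compound 3 (1.48 log units; beyond the scatter). Compound 4 `CCCCc1ccc(CNS(=O)(=O)c2ccccc2)c(=O)n1Cc1ccc(-c2ccccc2-c2nn[nH]n2)cc1` differs from compound 2 in one place: phenylsulfonyl in place of phenylcarbamoyl on an amine nitrogen. Among the measured compounds shown here, no measured step exchanges a carbonyl for a sulfonyl, so the bearing of the earlier steps is indirect. The step of a 3.0-fold higher number from compound 1 to compound 2 (0.48 log units; beyond the scatter) shows that a change at the carbonyl carbon moved this assay by only a modest amount, whereas the large step of a 30-fold lower number from compound 2 to compound 3 (1.48 log units; beyond the scatter) came with a different kind of change at the amine nitrogen. The expected step is therefore no change at the digits printed from compound 2 to compound 4 (within the scatter), small and uncertain in direction, in this assay. Compound 4 is estimated at 30 nM, with a range from 8 nM to 120 nM.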

Compound 4, half-maximal inhibitory concentration: 7 nM
Compound 4: middle estimate off by 4.3-fold (0.63 log units), on the high side, outside the stated range (below it).
By their numbers in this assay, from the lowest: compound 3; then compounds 4 and 1 (each within the scatter of the next); then compound 2.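

In this assay, among the compounds shown here, the exchange of phenylcarbamoyl for phenylsulfonyl on the amine nitrogen gives a 4.3-fold lower number from compound 2 to compound 4 (0.63 log units; beyond the scatter) and is the first step to replace the carbonyl with a sulfonyl at this position. The step of a 1.4-fold lower number from compound 1 to compound 4 (0.15 log units; within the scatter) leaves phenylsulfonyl and tert-butoxycarbonyl on this nitrogen indistinguishable here, so the phenylcarbamoyl of compound 2 is the group that stands apart from them. The change at the saturated chain carbon bound to an aromatic carbon gives a 7.0-fold higher number from compound 3 to compound 4 (0.85 log units; beyond the scatter) and leaves acetyl(benzyl)amino ahead of (phenylsulfonyl)amino.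

Still open, from the compounds shown here alone, is how a methylsulfonyl group would compare with phenylsulfonyl on this nitrogen, and whether a chlorine on the phenyl ring would shift the number. Nothing on hand offers an explanation for any of these steps.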